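The source may hold more compounds than are shown below. What is called first, only, known or untested is meant among the compounds shown, and "the series" means these compounds.

Compound 1 `Fc1ccc2[nH]c(-c3cn(-c4ccccc4)nc3-c3ccccc3)nc2c1`: 2430 nM
Compound 2 `O=C(OCc1ccccc1)c1ccc2[nH]c(-c3cn(-c4ccccc4)nc3-c3ccccc3)nc2c1`: 12600 nM
Compound 3 `Fc1ccc(-c2nn(-c3ccccc3)cc2-c2nc3cc(F)ccc3[nH]2)cc1`: 950 nM

All three compounds were measured in a functional assay on MCF7 cells (Homo sapiens) for antiproliferative activity, read by MTT assay, with a stated time of 48 h; on this read-out lower numbers stand for stronger inhibition and higher numbers for weaker inhibition. Compound 3 has the lowest number of the three, and its nearest neighbour on the scale is separated by a 2.6-fold lower number from compound 1 to compound 3 (0.41 log units; beyond the scatter). Compound 2 lies furthest away, with the highest number.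

The next compound, compound 4 `COc1ccc2[nH]c(-c3cn(-c4ccccc4)nc3-c3ccc(F)cc3)nc2c1`, has not yet been measured. It differs from compound 3 by methoxy in place of fluoro on an aromatic carbon. Within the data shown here, no measured step makes this exact exchange, so the evidence is indirect. The closest case replaces the same fluoro with benzyloxycarbonyl, giving a 5.2-fold higher number from compound 1 to compound 2 (0.71 log units; beyond the scatter). That is a modest rise, and it is a single example with a different incoming group. The other measured step, a 2.6-fold lower number from compound 1 to compound 3 (0.41 log units; beyond the scatter), adds a fluoro that compound 4 retains, so the lower level it reached should largely carry over. A small rise is therefore expected, smaller than the one seen with benzyloxycarbonyl, and the estimated change is a 1.8-fold higher number from compound 3 to compound 4 (0.25 log units; within the scatter). Compound 4 is estimated at 1700 nM, with an expected range from 600 nM to 4800 nM.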

Compound 4, half-maximal inhibitory concentration: 970 nM
Beside the measured number, compound 4's estimate is 1.8-fold (0.24 log units) above it, within the range that was stated.
By their numbers in this assay, from the lowest: compounds 3 and 4 (each within the scatter of the next); then compound 1; then compound 2.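

In this assay, methoxy in place of fluoro on this aromatic carbon gives a 1.0-fold higher number from compound 3 to compound 4 (0.01 log units; within the scatter) and so leaves the read-out unchanged within the scatter. Among these compounds, the only earlier exchange at this carbon, benzyloxycarbonyl in place of fluoro, gave a 5.2-fold higher number from compound 1 to compound 2 (0.71 log units; beyond the scatter) on a different starting compound, so the rise seen there does not follow from the loss of fluoro alone, at least when methoxy is the incoming group on compound 3. No measurement shown here explains why the two exchanges differ.

From the compounds shown here alone, it remains open whether methoxy would give the same result on compound 1, which lacks the second fluoro that compound 3 and compound 4 carry. Going by these compounds, it is also open where other groups on this carbon, such as an amine, a carboxylic acid or a longer ether chain, would fall relative to methoxy and benzyloxycarbonyl.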